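Adenosine deaminase inhibitors: phenyl substituent variation

A few compounds are considered here, and "the series" means these few. Any claim that something is new, unique, unknown or untested is made for them only; others in the source may bear on it.

Measured so far:
- compound 1 `C[C@H](O)[C@@H](CCc1ccc(C(F)(F)F)cc1)n1cnc2c(N)ncnc21`, an assay on isolated protein for inhibition of adenosine deaminase (Bos taurus), with a stated time of 5 min; a higher number here means a weaker inhibitor, a lower number a stronger inhibitor: 5.2 nM
- compound 2 `C[C@H](O)[C@@H](CCC1CCCCC1)n1cnc2c(N)ncnc21`, this assay: 1.9 nM
- compound 3 `C[C@H](O)[C@@H](CCc1cccc(-c2cnccn2)c1)n1cnc2c(N)ncnc21`, this assay: 1.9 nM

All three compounds share the same core and differ only in the group carried at the end of the two-carbon chain. The three numbers sit close together. Compound 3 and compound 2 are level at the digits shown, and together they hold the lowest values of the set; the gap between compound 3 and compound 2 lies within the scatter. Compound 1 stands furthest from compound 3, with a number beyond the scatter higher than that of compound 3.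

The next compound, compound 4 `C[C@H](O)[C@@H](CCc1cccc(C(=O)N2CCCC2)c1)n1cnc2c(N)ncnc21`, keeps the phenyl ring of compound 3 and changes its substituent: (pyrrolidin-1-yl)carbonyl in place of pyrazin-2-yl on an aromatic carbon.

For the measured compounds named here, no step between two measured compounds mirrors this change, so there is no computed guide for its size. The spread across compounds 1 to 3 is narrow, and a replacement at this position is expected to move the number little, if at all, beyond the scatter; a small shift toward a higher number is thought somewhat more likely than a lower one. The step from compound 3 to compound 4 is therefore estimated at a 1.6-fold higher number from compound 3 to compound 4 (0.20 log units; within the scatter). For compound 4 in this assay the expected value is 3 nM, with a range from 1.2 nM to 8 nM.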

Compound 4, inhibition constant: 2.2 nM
For compound 4 the middle estimate is 1.4-fold (0.13 log units) above the measured one; the measured number falls inside the stated range.
By their numbers in this assay, from the lowest: compounds 2, 3 and 4 (each within the scatter of the next); then compound 1.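

In this assay, the place on the phenyl ring meta to a large group takes two quite different substituents without separating the compounds: the exchange gives a 1.2-fold higher number from compound 3 to compound 4 (0.06 log units; within the scatter) and so leaves compound 3 and compound 4 indistinguishable. A number at this level therefore does not depend on pyrazin-2-yl being present, since (pyrrolidin-1-yl)carbonyl serves equally well with one five-membered non-aromatic ring in place of a six-membered aromatic ring, and with one hydrogen-bond acceptor in place of two. No available data bear on why the two substituents match.

Still open, from the compounds shown here alone, is whether this match extends to substituents of another kind at the same place, such as a carboxylic acid, a primary amine or a longer alkyl chain. Also open, going by these compounds, is how much of the pyrrolidine ring is needed within the carbonyl group, which a morpholine amide or a dimethylamide would address, and whether (pyrrolidin-1-yl)carbonyl would give a similar number at the ring position that carries trifluoromethyl in compound 1.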